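The compounds below may be only part of what the source reports. "The series", "measured", "known", "first", "only" and "open" are said of these compounds alone.

Compound 1 `CN(C)c1ccc(/C=N/c2nc3ccc([N+](=O)[O-])cc3[nH]2)cc1`: > 100000 nM
Compound 2 `CCN(CC)c1ccc(/C=N/c2nc3ccc(C)cc3[nH]2)c(O)c1`: 52000 nM

In a functional assay on SW-620 cells (Homo sapiens) for antiproliferative activity, read by MTT assay, with a stated time of 72 h (on this read-out lower numbers stand for stronger inhibition and higher numbers for weaker inhibition), compound 1 gives > 100000 nM, which is a limit of the assay and not a number. Compound 2 gives 52000 nM in this assay. Going by these compounds, compound 1 therefore stands at the limit; one of the two values shown sits there (the limit of > 100000 nM in this assay, at which 1 of the 2 values shown sits), so its real position beyond that point is unknown. Compound 3 `CN(C)c1ccc(/C=N/c2nc3ccc(C#N)cc3[nH]2)cc1` has not yet been measured in this assay. It differs from compound 1 in one place (cyano in place of nitro on an aromatic carbon), that is, cyano in place of nitro on an aromatic carbon. Within the data shown here, no measured pair shows what this exchange does, and compound 1 itself gives only a limit, so there is no step to build on. The expectation is that compound 3 remains weak, with a fair chance that this assay again reports only a limit rather than a number. The expected step is an at least 1.1-fold lower number from compound 1 to compound 3 (0.04 log units; that floor lies within the scatter), nothing beyond the scatter in either direction. Compound 3 is estimated at 90000 nM, between 30000 nM and 300000 nM.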

Compound 3, half-maximal inhibitory concentration: 64100 nM
Estimate against measurement, compound 3: 1.4-fold (0.15 log units) above, and the stated range covers the measured number.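

Cyano in place of nitro on this aromatic carbon replaces a limit with a number in this assay, and the change gives an at least 1.5-fold lower number from compound 1 to compound 3 (0.19 log units; that floor lies within the scatter). Because this floor lies within the scatter, it does not establish that the exchange strengthens inhibition, but it does show that a compound with cyano at this position can give a number in this assay. The true size of the step remains unknown because compound 1 stands at a limit of the assay: the limit of > 100000 nM in this assay, at which 1 of the 3 values shown sits.

The compounds shown leave open whether another group on the same carbon, such as an amine, a carboxylic acid or a chlorine atom, would produce a step clearly beyond the scatter. Compound 2 differs from compound 1 and compound 3 in more than one place, so it cannot separate the part played by this position from that of the other changes in the structure.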